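A few compounds are considered here, and "the series" means these few. Any claim that something is new, unique, unknown or untested is made for them only; others in the source may bear on it.

Measured so far in an ADME assay on a cell-free system (plasma, Mus musculus) for protein binding, using equilibrium dialysis:
Compound 1, `CC(C)c1noc(-c2cccc(CNc3ccc4[nH]nc(C(=O)O)c4c3)c2O)n1`: 99.6%
Compound 2, `CN(C)c1noc(-c2cccc(CNc3ccc4[nH]nc(C(=O)O)c4c3)c2Cl)n1`: 99.4%
Compound 3, `Cc1nc(-c2cccc(CN(C)c3ccc4[nH]nc(C(=O)O)c4c3)c2)sc1C`: 99.9%

Among these three, compound 1 with 99.6% holds the second highest unbound fraction. Compound 2 with 99.4% sits within the usual scatter of compound 1, so the two cannot be told apart. Compound 3 with 99.9% lies beyond the scatter and leaves a clearly smaller unbound fraction than compound 1.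

Compound 4, `CC(C)c1coc(-c2cccc(CNc3ccc4[nH]nc(C(=O)O)c4c3)c2O)n1`, has not yet been measured. It differs from compound 1 in a single place: 4-isopropyl-1,3-oxazol-2-yl in place of 3-isopropyl-1,2,4-oxadiazol-5-yl on an aromatic carbon. The isopropyl group stays, and the swap is confined to the five-membered aromatic ring that sits on an aromatic carbon of a six-membered aromatic ring of carbon only.

For the measured compounds named here, no pair of measured compounds shows what such a ring swap does here, so nothing beyond compound 1 itself can be leaned on. A change this small in this assay is expected to move the number little, most likely within the scatter, with a slight lean toward more binding. Compound 4 is therefore expected to give 99.7%, with a range from 99.3% to 99.9%. The expected step is a 1.3-fold lower unbound fraction from compound 1 to compound 4 (0.12 log units; within the scatter).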

Compound 4, plasma protein binding in the Mus musculus assay: > 99.7%
Compound 4 was reported as a limit; the forecaster's own chance of this, stated with the estimate: 5%; the middle value lies on the limit itself.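

In the Mus musculus assay compound 4 is reported as a limit of the assay, > 99.7%, and not as a number. In the Mus musculus assay the ring swap can therefore be read only as a floor, an at least 1.3-fold lower unbound fraction from compound 1 to compound 4 (0.12 log units; that floor lies within the scatter), so this change at this position leaves binding high but does not give the true size of the step. In a physicochemical assay for solubility, measured as kinetic solubility, at pH 2 (a lower number here means a less soluble compound, a higher number a more soluble compound), compound 1 gives 11000 nM and compound 4 gives 4000 nM, which shows that 4-isopropyl-1,3-oxazol-2-yl in place of 3-isopropyl-1,2,4-oxadiazol-5-yl, ortho to a hydroxy group, lowers solubility in this pair: the measured solubility of compound 1, 11000 nM, and of compound 4, 4000 nM, a 2.8-fold lower number (0.44 log units; beyond the scatter)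

From the compounds shown here alone, how much of compound 4 is really free stays open, and so does whether the same ring swap would act alike on a core without the hydroxy group. Also open, going by these compounds, is what a tert-butyl group or a longer chain in place of the isopropyl group would do to the binding and the solubility of compound 4.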